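The source may report more compounds than this note shows. Statements on the series, on what has been measured and on what is new or still open speak of the compounds shown alone.

Measured so far:
compound 1 `CCCOC(=O)C1=C(C)NC(=O)NC1c1cccs1`: 32%
compound 2 `CC1=C(C(=O)OC(C)(C)C)C(c2cccs2)NC(=O)N1`: 7%
compound 3 `CCCOC(=O)C1=C(C)NC(=S)NC1c1cccs1`: 10%

In an assay on membranes from HeLa cells for displacement of a labelled ligand from adenosine receptor A3 (Homo sapiens), read by scintillation counting, with a stated time of 180 min, tested at 1 uM (on this read-out lower numbers stand for less inhibition and higher numbers for more inhibition at the one concentration tested (going by the name of the read-out)), compound 1 gives 32%, while compound 2 gives 7%. The two differ in one place, (tert-butyl in place of propyl on an oxygen next to a carbonyl group), and the step is a number 25 percentage points lower from compound 1 to compound 2 (beyond the scatter). Compound 3 gives 10% in this assay; it differs from compound 1 in more than one place, and the difference between the two cores is not broken down here. Compound 3 and compound 2 lie within the scatter of each other, so nothing can be said about their order.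

Compound 4 `CC1=C(C(=O)OC(C)(C)C)C(c2cccs2)NC(=S)N1` has not yet been measured in this assay. It stands to compound 3 as compound 2 stands to compound 1, (tert-butyl in place of propyl on an oxygen next to a carbonyl group), the same change at the same place. For compound 4 the step is expected to be a number 7 percentage points lower from compound 3 to compound 4 (within the scatter), smaller in size than the earlier one because compound 3 already gives 10% and the read-out cannot fall far below nothing, even though the same change gave a number 25 percentage points lower from compound 1 to compound 2 (beyond the scatter). Compound 4 is therefore expected to give about 3% in this assay, most likely between -8% and 14%.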

Compound 4, a percentage reported as inhibition, at one concentration (the size of the read-out at that concentration, not a potency): 22%
Beside the measured number, compound 4's estimate is 19 percentage points below it; the whole stated range lies below it.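

In this assay, tert-butyl in place of propyl on an oxygen next to a carbonyl group gives a number 12 percentage points higher from compound 3 to compound 4 (beyond the scatter), so the change does not carry over from the core of compound 1 to the core of compound 3 with the same result. The two steps point in opposite directions and do not agree: the same change on two cores in this assay, a number 25 percentage points lower (beyond the scatter) from compound 1 to compound 2 and a number 12 percentage points higher (beyond the scatter) from compound 3 to compound 4, 37 percentage points apart, beyond the scatter of two such steps. This shows that, across these two pairs, the outcome of the change depends on the core that carries it, but it does not show why, and two pairs give no rule for any further core.

The compounds shown leave open how a longer chain or a benzyl group on the same oxygen would read out on either core, and whether such groups would follow the step on the core of compound 1 or the step on the core of compound 3. Also open, as far as these compounds go, is what a carboxylic acid or an amide would give at that place.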